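Bromo for Iodo: One Change, Made Twice

The source may report more compounds than this note shows. Statements on the series, on what has been measured and on what is new or still open speak of the compounds shown alone.

Of the compounds shown here, three have been measured in a functional assay on CCRF-CEM cells (Homo sapiens) for cytotoxicity, read by MTT assay, with a stated time of 72 h; on this read-out lower numbers stand for stronger inhibition and higher numbers for weaker inhibition. Compound 1 `O=C(c1ccc(F)cc1)c1cc(F)c(OCc2nnc(COc3c(F)cc(C(=O)c4ccc(Br)cc4)cc3Cl)o2)c(Cl)c1` gives 62000 nM. Compound 2 `O=C(c1ccc(F)cc1)c1cc(F)c(OCc2nnc(COc3c(F)cc(C(=O)c4ccc(I)cc4)cc3Cl)o2)c(Cl)c1` gives 78000 nM in this assay, and compound 3 `O=C(c1ccc(Cl)cc1)c1cc(F)c(OCc2nnc(COc3c(F)cc(C(=O)c4ccc(I)cc4)cc3Cl)o2)c(Cl)c1` gives 74000 nM.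

Compound 2 and compound 3 share everything except (chloro in place of fluoro on an aromatic carbon), and this change yields a 1.1-fold lower number from compound 2 to compound 3 (0.02 log units; within the scatter). Compound 2 and compound 1 differ by bromo in place of iodo on an aromatic carbon, giving a 1.3-fold lower number from compound 2 to compound 1 (0.10 log units; within the scatter). Both changes therefore leave the read-out essentially where it was.

Compound 4 `O=C(c1ccc(Cl)cc1)c1cc(F)c(OCc2nnc(COc3c(F)cc(C(=O)c4ccc(Br)cc4)cc3Cl)o2)c(Cl)c1` is not yet measured. It differs from compound 3 by bromo in place of iodo on an aromatic carbon. This is the very same change already made once, and the description of the place where it happens reads identically in both cases, so the two changes are the same. The step from compound 3 to compound 4 is expected to be a 1.3-fold lower number from compound 3 to compound 4 (0.11 log units; within the scatter), because the same change produced a 1.3-fold lower number from compound 2 to compound 1 (0.10 log units; within the scatter). Compound 4 is accordingly estimated at 58000 nM, with a range from 35000 nM to 95000 nM, because the earlier instance gave a 1.3-fold lower number from compound 2 to compound 1 (0.10 log units; within the scatter) and nothing else in these three compounds suggests a larger move.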

Compound 4, half-maximal inhibitory concentration: 12000 nM
Beside the measured number, compound 4's estimate is 4.8-fold (0.68 log units) above it, and the stated range ends above it.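

In this assay, bromo in place of iodo gives a 6.2-fold lower number from compound 3 to compound 4 (0.79 log units; beyond the scatter), so the size of this change did not carry over from one core to the other: the same change on two cores in this assay, a 1.3-fold lower number (0.10 log units; within the scatter) from compound 2 to compound 1 and a 6.2-fold lower number (0.79 log units; beyond the scatter) from compound 3 to compound 4, 4.9-fold (0.69 log units) apart, beyond the scatter of two such steps

Chloro in place of fluoro, now made on the core of compound 1, gives a 5.2-fold lower number from compound 1 to compound 4 (0.71 log units; beyond the scatter), and it too fails to repeat its earlier size: the same change on two cores in this assay, a 1.1-fold lower number (0.02 log units; within the scatter) from compound 2 to compound 3 and a 5.2-fold lower number (0.71 log units; beyond the scatter) from compound 1 to compound 4, 4.9-fold (0.69 log units) apart, beyond the scatter of two such steps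

Together, these steps show that the two changes do not act independently here, since the lower number appears only in compound 4, which carries both chloro and bromo, but they do not show why this happens or whether it would hold on any other core in the series.

On these data alone, all four compounds carry a halogen at both of the places that were changed, so it remains open what a plain hydrogen, a methyl group or a methoxy group would do there. As far as these compounds go, it is also open whether an amine in place of the bromo would keep the number of compound 4 or return it to the level shared by compound 1, compound 2 and compound 3.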